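The source may report more compounds than this note shows. Statements on the series, on what has been measured and on what is new or still open speak of the compounds shown alone.

Working notes on a urea series. In an ADME assay on Raji cells (Homo sapiens) for cytotoxicity, with a stated time of 72 h (on this read-out lower numbers stand for an effect already at smaller amounts and higher numbers for an effect only at larger amounts of compound), compound 1 `Cc1cc(NC(=O)Nc2cc(Cl)cc(Cl)c2)c2ccccc2n1` gives only a limit, > 25000 nM. Compound 2 `COc1ccccc1NC(=O)Nc1cc(C)nc2ccccc12` likewise gives only a limit, > 25000 nM. Among the compounds with values here, compound 1 stands at the limit of > 25000 nM in this assay, at which 2 of the 2 values shown sit, and no step between measured compounds is at hand. Compound 3 `Cc1cc(NC(=O)Nc2cccc(Cl)c2)c2ccccc2n1` differs from compound 1 by hydrogen in place of chloro on an aromatic carbon. In this assay no step beyond the scatter is expected from compound 1 to compound 3; the expected step is a step that the limit leaves unreadable from compound 1 to compound 3. Compound 3 is estimated at 30000 nM, with a range from 12000 nM to 80000 nM, and it is expected to come back mainly as a limit again.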

Compound 3, half-maximal effective concentration: 18000 nM
Compound 3: middle estimate off by 1.7-fold (0.22 log units), on the high side; the range from low to high includes it.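

With hydrogen in place of chloro on this aromatic carbon, meta to a chloro group, compound 3 gives the first number rather than a limit in this assay. The change reads as an at least 1.3-fold lower number from compound 1 to compound 3 (0.14 log units; that floor lies within the scatter), so no shift beyond the scatter is established. The true size of the step cannot be read, as compound 1 gives only a limit: the limit of > 25000 nM in this assay, at which 2 of the 3 values shown sit.

Open, on these data alone, is how the read-out responds when an amine or a carboxylic acid sits on this carbon. Also open, as far as these compounds go, is what the remaining chloro of compound 3 contributes.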